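This account rests on a few compounds, and the source may have more. Where it says the series, first, only, none or still open, it means among the compounds named here.

Measured in a functional assay on A-431 cells (Homo sapiens) for antiproliferative activity, read by MTT assay, with a stated time of 72 h; on this read-out lower numbers stand for stronger inhibition and higher numbers for weaker inhibition:
compound 1 `CN1CCN(Cc2ccc(NC(=O)Nc3ccc4ncnc(Nc5ccc(F)c(Cl)c5)c4c3)cc2)CC1`: 4000 nM
compound 2 `CN1CCN(Cc2ccc(NC(=O)Nc3ccc4ncnc(Nc5cccc(C(F)(F)F)c5)c4c3)cc2)CC1`: 2410 nM
compound 3 `COC(=O)c1cccc(Nc2ncnc3ccc(NC(=O)Nc4ccc(CN5CCN(C)CC5)cc4)cc23)c1`: 5630 nM

Compound 2 sits at one end of the three numbers: the step of a 1.7-fold lower number from compound 1 to compound 2 (0.22 log units; within the scatter) lies within the scatter, whereas the step of a 2.3-fold higher number from compound 2 to compound 3 (0.37 log units; beyond the scatter) lies beyond it. All three measured steps, including a 1.4-fold higher number from compound 1 to compound 3 (0.15 log units; within the scatter), vary only the aryl group on the nitrogen on the aromatic ring of the shared core. Compound 4 `CN(C)Cc1ccc(NC(=O)Nc2ccc3ncnc(Nc4cccc(C(F)(F)F)c4)c3c2)cc1` changes a different part of the molecule: dimethylamino in place of 4-methylpiperazin-1-yl on a saturated chain carbon bound to an aromatic carbon. Going by the values given here, no measured step touches this position, so the series gives no direction for it. The expectation is therefore a step of a 1.0-fold lower number from compound 2 to compound 4 (0.00 log units; within the scatter) that stays within the scatter in this assay. Compound 4 is estimated at 2400 nM, with a range from 1000 nM to 6000 nM.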

Compound 4, half-maximal inhibitory concentration: 1030 nM
Beside the measured number, compound 4's estimate is 2.3-fold (0.37 log units) above it; the range from low to high includes it.
By their numbers in this assay, from the lowest: compound 4; then compounds 2, 1 and 3 (each within the scatter of the next, the first and the last beyond it).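

In this assay, the side chain also moves the number: the change from (4-methylpiperazin-1-yl)methyl to (dimethylamino)methyl gives a 2.3-fold lower number from compound 2 to compound 4 (0.37 log units; beyond the scatter), a modest step. With the 3-(trifluoromethyl)phenyl group in place, the six-membered ring is therefore not needed to keep this level of activity, and the smaller group does better. Nothing measured here bears on why the number falls.

From the compounds shown here alone, it remains open whether the step carries over to the 3-chloro-4-fluorophenyl or 3-(methoxycarbonyl)phenyl compounds. Also open, going by these compounds, is how a morpholine, a pyrrolidine or a primary amine would read at this position.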